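Series notes: cyclopropyl on the sulfonyl in compound 4

This account rests on a few compounds, and the source may have more. Where it says the series, first, only, none or still open, it means among the compounds named here.

Compound 3 `CC(C)C(=O)NCCS(=O)(=O)NC(=O)c1ccc(Nc2nc(NC3(c4ccc(Cl)cc4)CC3)nc(OCC(F)(F)F)n2)cc1` gives 86% in an ADME assay on microsomes from liver (Homo sapiens) for metabolic stability, with a stated time of 10 min; on this read-out lower numbers stand for a less stable compound and higher numbers for a more stable compound. Among the three numbers so far it stands second highest: compound 2 `CC(C)(C)OC(=O)NCCS(=O)(=O)NC(=O)c1ccc(Nc2nc(NC3(c4ccc(Cl)cc4)CC3)nc(OCC(F)(F)F)n2)cc1` gives 92%, within the scatter of compound 3, and compound 1 `CCCCCNc1nc(Nc2ccc([N+](=O)[O-])cc2)nc(OCC(F)(F)F)n1` gives 74%, beyond the scatter below compound 3. Within the data shown here, the only measured step that alters the chain on the sulfonyl sulfur, a number 6 percentage points lower from compound 2 to compound 3 (within the scatter), stayed within the scatter.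

Compound 4 `O=C(NS(=O)(=O)C1CC1)c1ccc(Nc2nc(NC3(c4ccc(Cl)cc4)CC3)nc(OCC(F)(F)F)n2)cc1` differs from compound 3 by cyclopropyl in place of 2-((isopropylcarbonyl)amino)ethyl on a sulfonyl sulfur. Among the measured compounds shown here, that step bears on the same place, but no measured pair exchanges the whole chain for a ring, nor removes the carbonyl amino part of the chain altogether. Compound 1 carries no acylsulfonamide piece at all and differs in more than one place, so its lower value cannot be tied to this change. Given that the one relevant step was small, compound 4 is expected to show a step of a number 4 percentage points lower from compound 3 to compound 4 (within the scatter), within the scatter. For compound 4 the estimate is 82%, with a range from 65% to 95%.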

Compound 4, percent of the compound remaining: 100%
Beside the measured number, compound 4's estimate is 18 percentage points below it; measured number above the stated range.
By their numbers in this assay, from the lowest: compound 1; then compounds 3, 2 and 4 (each within the scatter of the next, the first and the last beyond it).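

At the sulfonyl sulfur, the change from a chain to a ring gives in this assay a step that clears the scatter: a number 14 percentage points higher from compound 3 to compound 4 (beyond the scatter) with cyclopropyl in place of 2-((isopropylcarbonyl)amino)ethyl, whereas the earlier change at the far end of the chain did not clear it. The same ring set against the chain of compound 2 gives a number 8 percentage points higher from compound 2 to compound 4 (within the scatter) and so separates less clearly, which means the reading of this change depends on which chain leaves. No measurement available here accounts for either step.

On these data alone, it remains open whether the ring itself or the loss of the chain's carbonyl amino part carries the step. An ethyl or isopropyl group on the sulfonyl sulfur, or a free 2-aminoethyl chain there, would separate these two readings.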